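Aryl swap on the triazole-bearing nitrogen in a weak series

The compounds below may be only part of what the source reports. "The series", "measured", "known", "first", "only" and "open" are said of these compounds alone.

The series shares the core of compound 1 `Cc1cccc(-n2cc(CNC(=O)c3cccc4c3cnn4C(C)C)nn2)c1` and compound 2 `CC(C)n1ncc2c(C(=O)NCc3cn(-c4ccccc4F)nn3)cccc21`. In a functional assay on PC-3 cells (Homo sapiens) for inhibition, read by MTT assay, with a stated time of 72 h (a higher number here means a weaker inhibitor, a lower number a stronger inhibitor), compound 1 gives 32300 nM. Compound 2 reaches only a limit of the assay, > 40000 nM, and stands at the limit of > 40000 nM in this assay, at which 1 of the 2 values shown sits, so no number is known for it. Among the compounds with values here, the one measured step, an at least 1.2-fold higher number from compound 1 to compound 2 (0.09 log units; that floor lies within the scatter), is therefore open-ended. The next compound, compound 3 `CC(C)n1ncc2c(C(=O)NCc3cn(-c4ccc(C(F)(F)F)cc4)nn3)cccc21`, differs from compound 2 by 4-(trifluoromethyl)phenyl in place of 2-fluorophenyl on an aromatic nitrogen. Within the data shown here, no measured step covers a 4-(trifluoromethyl)phenyl group; the only measured step moves between two aryl groups on the same aromatic nitrogen and keeps the number at or beyond the limit. For compound 3 no step beyond the scatter is expected in this assay, and the estimate for compound 3 is 40000 nM, with a range from 15000 nM to 110000 nM. The expected step of a number no higher from compound 2 to compound 3 (the limit leaves the size open) is thus small, with a fair chance of only a limit again.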

Compound 3, half-maximal inhibitory concentration: 38600 nM
Beside the measured number, compound 3's estimate is 1.0-fold (0.02 log units) above it, within the range that was stated.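

As far as these compounds go, on the aromatic nitrogen, 4-(trifluoromethyl)phenyl in place of 3-methylphenyl gives a 1.2-fold higher number from compound 1 to compound 3 (0.08 log units; within the scatter) in this assay, so two differently substituted phenyl groups now carry actual numbers at this position, and those numbers cannot be told apart. 4-(trifluoromethyl)phenyl in place of 2-fluorophenyl gives an at least 1.0-fold lower number from compound 2 to compound 3 (0.01 log units; that floor lies within the scatter), a step that stays open-ended. Compound 2 remains a limit and not a number: the limit of > 40000 nM in this assay, at which 1 of the 3 values shown sits.

The compounds shown leave open whether any other group on this nitrogen, such as a phenyl ring bearing an amine or a carboxylic acid, or a plain alkyl chain in place of the ring, would move the number in this assay beyond the scatter. From the compounds shown here alone, it also remains open whether the true value of compound 2 lies close to the other two.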